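From methyl to phenyl on the shared core

This account rests on a few compounds, and the source may have more. Where it says the series, first, only, none or still open, it means among the compounds named here.

- Compound 1 `CC(=O)Oc1ccc2c(c1)C(C)=CC(C)(C)N2Cc1ccccc1` gives 18000 nM here
- Compound 2 `CC(=O)Oc1ccc2c(c1)C(C)=CC(C)(C)N2Cc1ccc(F)c(F)c1` gives 17000 nM here
- Compound 3 `CC(=O)Oc1ccc2c(c1)C(C)=CC(C)(C)N2Cc1ccc(C(C)C)cc1` gives 10000 nM here
- Compound 4 `CC(=O)Oc1ccc2c(c1)C(c1ccccc1)=CC(C)(C)N2Cc1ccccc1` is still unmeasured

In an ADME assay on L6 cells (Rattus norvegicus) for cytotoxicity, read by resazurin assay, with a stated time of 70 h (a higher number here means a weaker inhibitor, a lower number a stronger inhibitor), compound 1 stands level with its two neighbours, with a 1.1-fold lower number from compound 1 to compound 2 (0.02 log units; within the scatter) and a 1.8-fold lower number from compound 1 to compound 3 (0.26 log units; within the scatter) as the steps away from it. Compound 4 differs from compound 1 by phenyl in place of methyl on a double-bonded ring carbon as the change, phenyl in place of methyl on a double-bonded ring carbon. Within the data shown here, no measured step touches that carbon. Among the measured compounds shown here, the only guides are changes on the benzyl group, where a 1.7-fold lower number from compound 2 to compound 3 (0.23 log units; within the scatter) also stayed small. Only a slight shift towards a lower number is therefore expected in this assay, with none beyond the scatter firmly predicted. The estimate for compound 4 is 11000 nM as the middle, within an expected range of 4000 nM to 25000 nM overall. That estimate means a 1.6-fold lower number from compound 1 to compound 4 (0.21 log units; within the scatter) as the expected step.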

Compound 4, half-maximal inhibitory concentration: 49000 nM
The estimate for compound 4 lay 4.5-fold (0.65 log units) below the measured number; the measured number lies above the stated range.
By their numbers in this assay, from the lowest: compounds 3, 2 and 1 (each within the scatter of the next); then compound 4.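

In this assay, phenyl in place of methyl on the double-bonded ring carbon gives a 2.7-fold higher number from compound 1 to compound 4 (0.43 log units; beyond the scatter), the only step among these compounds that lies beyond the scatter. The other steps all change the benzyl group and stay within the scatter, so this is the one position here shown to shift the number, and the shift is towards weaker inhibition. No available evidence bears on this result.

As far as these compounds go, it remains open whether an ethyl group or a pyridine ring at this carbon would shift the number as phenyl does. From the compounds shown here alone, it is also open whether the same change would give a similar step with the 3,4-difluorophenyl or 4-isopropylphenyl groups in place of the phenyl of the benzyl group.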